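The compounds below may be only part of what the source reports. "The series", "measured", "known", "first", "only" and "open" are said of these compounds alone.

Compound 1 `O=C(CCCCCc1ccccc1)c1nc2ccc([N+](=O)[O-])cc2o1`: 87.1 nM
Compound 2 `O=C(CCCCCCc1ccccc1)c1nc(C(=O)C(F)(F)F)co1`: 123 nM
Compound 3 `CC(=O)c1cnc(C(=O)CCCCCCc2ccccc2)o1`: > 10000 nM

In an assay on HEK-293T cells for inhibition of diacylglycerol lipase-alpha (Homo sapiens), read by colorimetric assay (on this read-out higher numbers stand for weaker inhibition and lower numbers for stronger inhibition), compound 1 gives 87.1 nM and compound 2 gives 123 nM; these two values lie within the usual scatter of each other. Compound 3 stands apart from them: for compound 3 this assay reports only a limit, > 10000 nM, and not a number, so that the limit of > 10000 nM in this assay, at which 1 of the 3 values shown sits, is all that is known of it.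

The step to compound 4 `O=C(CCCCCCc1ccccc1)c1ncc(-c2ccc(F)cc2)o1` is 4-fluorophenyl in place of acetyl on an aromatic carbon. Within the data shown here, no measured pair with a matching change is available, so the size of this step can only be expected, not read off. Compounds 1 and 2, which carry other groups on their cores, both return numbers well inside the range of this assay, while compound 3 with its acetyl group does not; on that basis a move back into the measurable range, that is towards stronger inhibition, is what is expected of compound 4.

Compound 4 is therefore expected to give about 400 nM in this assay, with a range from 50 nM to 5000 nM, which would amount to an estimated step of an at least 25-fold lower number from compound 3 to compound 4 (1.39 log units; beyond the scatter).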

Compound 4, half-maximal inhibitory concentration: > 10000 nM
Compound 4: a limit, no number; the forecaster's own chance of this, stated with the estimate: 25%; middle value at least 25-fold (1.39 log units) from the limit.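

In this assay compound 4 gives only a limit of > 10000 nM and not a number. Among these compounds, compound 3 is also known only by a limit, so no step between compound 3 and compound 4 can be read. The compounds shown leave open how strongly either compound inhibits, and whether any other group in that place returns a measurable number.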